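Triazole series: cytotoxicity in PC-12 cells, aryl variation

The source may report more compounds than this note shows. Statements on the series, on what has been measured and on what is new or still open speak of the compounds shown alone.

The measured compounds and their values:

compound 1, `Oc1cc(C(F)(F)F)ccc1-c1nc(-c2ccccc2O)n(-c2ccc(Br)cc2)n1`, 89.8%
compound 2, `COc1ccccc1-n1nc(-c2ccc(C(F)(F)F)cc2O)nc1-c1ccccc1O`, 85.6%
compound 3, `Oc1cc(C(F)(F)F)ccc1-c1nc(-c2ccccc2O)n(-c2cccc(Cl)c2)n1`, 92.7%

In a functional assay on PC-12 cells (Rattus norvegicus) for cytotoxicity, read by MTT assay, with stated times of 2 h and 24 h, tested at 5 uM (on this read-out higher numbers stand for a stronger effect at the one concentration tested and lower numbers for a weaker effect), compound 3 gives the highest of the three numbers, yet its nearest neighbour, compound 1, sits only a number 2.9 percentage points higher from compound 1 to compound 3 (within the scatter), and compound 2 lies a number 7.1 percentage points higher from compound 2 to compound 3 (within the scatter), both within the scatter. Compound 4, `Cc1cc(C)cc(-n2nc(-c3ccc(C(F)(F)F)cc3O)nc2-c2ccccc2O)c1`, differs from compound 3 in one place: 3,5-dimethylphenyl in place of 3-chlorophenyl on an aromatic nitrogen. Every measured step concerns the same aromatic nitrogen and the aryl group on it: a number 4.2 percentage points lower from compound 1 to compound 2 (within the scatter), a number 2.9 percentage points higher from compound 1 to compound 3 (within the scatter) and a number 7.1 percentage points higher from compound 2 to compound 3 (within the scatter). None of them moved the read-out beyond the scatter, so a further change of the aryl group at this position is expected to leave the number where it is. For compound 4 the expected step in this assay is therefore a number 3.7 percentage points lower from compound 3 to compound 4 (within the scatter), which is no change beyond the scatter. Compound 4 is estimated at 89%, within a range from 78% to 97%.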

Compound 4, a percentage reported as activity, at one concentration (the size of the read-out at that concentration, not a potency): 102%
Estimate against measurement, compound 4: 13 percentage points below; measured number above the stated range.
By their numbers in this assay, from the lowest: compounds 2, 1, 3 and 4 (each within the scatter of the next, the first and the last beyond it).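

In this assay, for the compounds shown here, the aryl group on this aromatic nitrogen now gives the first steps beyond the scatter, though modest ones: 3,5-dimethylphenyl in place of 2-methoxyphenyl (a number 16.4 percentage points higher from compound 2 to compound 4 (beyond the scatter)) and in place of 4-bromophenyl (a number 12.2 percentage points higher from compound 1 to compound 4 (beyond the scatter)). The change from 3-chlorophenyl stays within the scatter (a number 9.3 percentage points higher from compound 3 to compound 4 (within the scatter)), so the position is not silent, yet compound 4 cannot be set apart from compound 3. Nothing available explains why the read-out moves with 3,5-dimethylphenyl.

Going by these compounds, whether a single methyl group, an amine or a carboxylic acid on this phenyl ring, or a longer chain in place of the ring, would shift the number remains open. All the compounds shown keep the trifluoromethyl group and both hydroxyl groups, so what changes at those places would do is also unknown.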